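Swapping Ethyl for Formyl in Compound 3

A few compounds are considered here, and "the series" means these few. Any claim that something is new, unique, unknown or untested is made for them only; others in the source may bear on it.

In a functional assay on OVCAR-3 cells (Homo sapiens) for inhibition, read by sulforhodamine B assay, with a stated time of 48 h, tested at 10 uM (on this read-out higher numbers stand for more inhibition at the one concentration tested (going by the name of the read-out) and lower numbers for less inhibition), three compounds have been measured so far. Compound 1 `Brc1cn2ccnc2c(-c2ccc3ncn(C4CCCCC4)c3c2)n1` gives 15.8%, compound 2 `COc1ccc(-c2cn3ccnc3c(-c3ccc4ncn(C5CCCCC5)c4c3)n2)cc1` gives -26.5%, and compound 3 `CCc1ccc(-c2cn3ccnc3c(-c3ccc4ncn(Cc5ccccc5)c4c3)n2)cc1` gives 31.2%. Going by the values given here, the single recorded step between two compounds that differ in one place is a number 42.3 percentage points lower from compound 1 to compound 2 (beyond the scatter). Compound 3 stands highest of the three numbers; compound 1 is nearest to it, with a gap beyond the scatter, and compound 2 is furthest.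

Compound 4 `O=Cc1ccc(-c2cn3ccnc3c(-c3ccc4ncn(Cc5ccccc5)c4c3)n2)cc1` differs from compound 3 in one place: formyl in place of ethyl on an aromatic carbon. Among the compounds with values here, no measured step involves this kind of change; the one step recorded concerns a different group at a different position, so it does not carry over. The expectation is therefore an uncertain, moderate move, estimated as a number 11.2 percentage points lower from compound 3 to compound 4 (beyond the scatter). Compound 4 is expected to give 20%, with a range from -15% to 50%.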

Compound 4, a percentage reported as inhibition, at one concentration (the size of the read-out at that concentration, not a potency): 23.7%
Beside the measured number, compound 4's estimate is 3.7 percentage points below it; the measured number falls inside the stated range.
By their numbers in this assay, from the lowest: compound 2; then compounds 1, 4 and 3 (each within the scatter of the next, the first and the last beyond it).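

In this assay the change from 4-ethylphenyl to 4-formylphenyl gives a number 7.5 percentage points lower from compound 3 to compound 4 (within the scatter), so at this position, para to a large group, the two groups cannot be told apart on this read-out. Formyl brings a hydrogen-bond acceptor and a double bond outside the aromatic rings that ethyl lacks, yet neither addition produces a step beyond the usual scatter here. No separate evidence is available on why the two groups read alike.

As far as these compounds go, it remains open whether an amine, a carboxylic acid or a longer chain at this position would also read like ethyl and formyl. From the compounds shown here alone, it is also open whether the same swap would read alike if the cyclohexyl group of compound 2 replaced the benzyl group shared by compound 3 and compound 4.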